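The source may hold more compounds than are shown below. What is called first, only, known or untested is meant among the compounds shown, and "the series" means these compounds.

Compound 1 `O=C(Nc1ccc(Cl)cc1)Nc1cccc(-c2nc(-c3ccc(NC(=O)c4cccnc4)cc3Cl)no2)c1` — in a functional assay on MDA-MB-231 cells (Homo sapiens) for antiproliferative activity, read by MTT assay, with a stated time of 72 h (on this read-out lower numbers stand for stronger inhibition and higher numbers for weaker inhibition), compound 1 gives > 10000 nM, which is a limit of the assay rather than a number.
Compound 2 `O=C(Nc1cccc(-c2nc(-c3ccc(NC(=O)c4cccnc4)cc3Cl)no2)c1)Nc1ccc(Cl)c(C(F)(F)F)c1` — compound 2 gives 1900 nM.
Compound 3 `NS(=O)(=O)Nc1ccc(NC(=O)Nc2cccc(-c3nc(-c4ccc(NC(=O)c5cccnc5)cc4Cl)no3)c2)cc1` — compound 3 gives 8900 nM.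

Compound 3 holds the highest of the two numbers in this assay. Its nearest neighbour is reached by a 4.7-fold higher number from compound 2 to compound 3 (0.67 log units; beyond the scatter), the change being 4-(sulfamoylamino)phenyl in place of 4-chloro-3-(trifluoromethyl)phenyl on an amide-type nitrogen. The other step into compound 3 is an at least 1.1-fold lower number from compound 1 to compound 3 (0.05 log units; that floor lies within the scatter), sulfamoylamino in place of chloro on an aromatic carbon, and its floor rests on (the limit of > 10000 nM in this assay, at which 1 of the 3 values shown sits).

Compound 4 `CC(=O)Nc1ccc(NC(=O)Nc2cccc(-c3nc(-c4ccc(NC(=O)c5cccnc5)cc4Cl)no3)c2)cc1` differs from compound 3 by acetyl in place of sulfamoyl on a nitrogen on an aromatic ring. Both measured steps that touch this end of the molecule point the same way: swapping the group on this outer ring moved the number only modestly or not beyond the scatter. Neither step compares acetyl against sulfamoyl directly, so the expectation for compound 4 is cautious: no change beyond the scatter, expressed as a 1.0-fold higher number from compound 3 to compound 4 (0.00 log units; within the scatter). Compound 4 is therefore estimated at 9000 nM, within a range from 3000 nM to 25000 nM.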

Compound 4, half-maximal inhibitory concentration: > 10000 nM
Compound 4: no number, only a limit; the forecaster's own chance of this, stated with the estimate: 40%; middle value at least 1.1-fold (0.04 log units) away from the limit.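

In this assay compound 4 stands only as a limit of the assay, not as a number. Acetyl in place of sulfamoyl gives an at least 1.1-fold higher number from compound 3 to compound 4 (0.05 log units; that floor lies within the scatter), so this swap on the nitrogen does not separate the two groups, and the true size of the step cannot be read beyond that floor: the limit of > 10000 nM in this assay, at which 2 of the 4 values shown sit. The 4-acetamidophenyl group, like the 4-(sulfamoylamino)phenyl group, falls short of the 4-chloro-3-(trifluoromethyl)phenyl group, with an at least 5.2-fold higher number from compound 2 to compound 4 (0.72 log units; beyond the scatter), while the step between compound 1 and compound 4 cannot be read, as both values are limits.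

From the compounds shown here alone, how far compound 4 really lies from compound 3 stays open. So does whether a methylsulfonyl group or a longer acyl chain such as butanoyl on the same nitrogen would give a measurable number.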